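Swapping acetyl for cyano on an indole vinyl sulfone

The compounds below may be only part of what the source reports. "The series", "measured", "known", "first", "only" and "open" are said of these compounds alone.

Of the compounds shown here, two have been measured in a functional assay on MDA-MB-435 cells (Homo sapiens) for inhibition, read by sulforhodamine B assay, with a stated time of 48 h; a higher number here means a weaker inhibitor of growth, a lower number a stronger inhibitor of growth. Compound 1 `COc1ccc(-c2[nH]c3ccc(OC)cc3c2/C=C(\C#N)S(=O)(=O)c2ccccc2)cc1` gives 276 nM. Compound 2 `CC(=O)/C(=C\c1c(-c2ccccc2)[nH]c2ccccc12)S(=O)(=O)c1ccccc1`, which carries no methoxy groups and an acetyl group on the chain, gives 295 nM. On these two numbers compound 2 stands at essentially the same level as compound 1; the gap between them lies within the scatter of the measurement, so neither can be called the stronger inhibitor.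

Compound 3 `N#C/C(=C\c1c(-c2ccccc2)[nH]c2ccccc12)S(=O)(=O)c1ccccc1` has not yet been measured. It differs from compound 2 in one place: cyano in place of acetyl on a double-bonded chain carbon bound to a double-bonded chain carbon and a sulfonyl sulfur. Within the data shown here, no measured pair shows this change on its own, so no step can be read off. Since compound 1, which also carries cyano on that chain carbon, gives 276 nM, the change from compound 2 to compound 3 is expected to produce no step beyond the scatter, a 1.2-fold lower number from compound 2 to compound 3 (0.07 log units; within the scatter). Compound 3 is therefore estimated at 250 nM, between 100 nM and 650 nM.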

Compound 3, concentration for 50% growth inhibition: 288 nM
The estimate for compound 3 lay 1.2-fold (0.06 log units) below the measured number; low and high end bracket the measured number.
By their numbers in this assay, from the lowest: compounds 1, 3 and 2 (each within the scatter of the next).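

In this assay, putting cyano in place of acetyl on a double-bonded chain carbon bound to a double-bonded chain carbon and a sulfonyl sulfur gives a 1.0-fold lower number from compound 2 to compound 3 (0.01 log units; within the scatter). Among these compounds, this pair is the first to show this change on its own, and at this position the two groups cannot be told apart in this assay, although acetyl has 3 heavy atoms and a double bond while cyano has 2 heavy atoms and a triple bond. No measurement is available to explain this result.

As far as these compounds go, whether a carboxylic acid, an amine or a longer chain at the same carbon would also fit in this range remains open. Compound 1 differs from compound 3 in more than one place, so the effect of its methoxy groups cannot be read.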